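A few compounds are considered here, and "the series" means these few. Any claim that something is new, unique, unknown or untested is made for them only; others in the source may bear on it.

Measured compounds:
- compound 1, `COc1ccc(/C=C/C2CC=CC(=O)O2)cc1`: 61.5 uM
- compound 2, `O=C1C=CCC(/C=C/c2ccccc2)N1`: > 1250 uM
- compound 3, `O=C1C=CCC(/C=C/c2ccccc2C(F)(F)F)N1`: 329 uM

In a functional assay on OVCAR-3 cells (Homo sapiens) for inhibition, read by sulforhodamine B assay, with a stated time of 48 h (a lower number here means a stronger inhibitor of growth, a higher number a weaker inhibitor of growth), compound 1 gives 61.5 uM. For the measured compounds named here, for compound 2 only a limit is known in this assay, > 1250 uM, and it is the one value of the three sitting at the limit of > 1250 uM in this assay, at which 1 of the 3 values shown sits. Compound 3, which carries a trifluoromethyl on an aromatic carbon of the same ring, gives 329 uM in this assay; the step is an at least 3.7-fold lower number from compound 2 to compound 3 (0.57 log units; beyond the scatter).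

The unmeasured compound 4, `O=C1C=CCC(/C=C/c2ccc(C(F)(F)F)cc2)N1`, differs from compound 2 by trifluoromethyl in place of hydrogen on an aromatic carbon. Going by the values given here, the only measured step that bears on it is the one from compound 2 to compound 3, the same kind of change at another aromatic carbon, and that step was at least modest toward a lower number. A step of similar size in this assay is therefore expected for compound 4, downward from the limit, with an at least 4.1-fold lower number from compound 2 to compound 4 (0.61 log units; beyond the scatter) as the expected change. Compound 4 is thus estimated at 300 uM, with a range from 90 uM to 1250 uM, the limit of compound 2 marking the weak end of what seems plausible.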

Compound 4, concentration for growth inhibition (reported as GI): 126 uM
Compound 4: the middle estimate sits 2.4-fold (0.38 log units) above what was measured, within the range that was stated.
By their numbers in this assay, from the lowest: compound 1; then compound 4; then compound 3. At a limit, above all of these: compound 2.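

Trifluoromethyl in place of hydrogen, para to a group of 9 heavy atoms, gives an at least 9.9-fold lower number from compound 2 to compound 4 (0.99 log units; beyond the scatter) in this assay, so the downward step is no longer tied to a single aromatic carbon. With the same group on another aromatic carbon of that ring, compound 3 gives 329 uM, whereas compound 4 gives 126 uM, so the number depends on where the group sits as well as on its presence. The size of the step remains a bound and not a measured difference: the limit of > 1250 uM in this assay, at which 1 of the 4 values shown sits.

From the compounds shown here alone, whether a nitrile, an amine or a carboxylic acid on this carbon would also lower the number remains open. Going by these compounds, compound 1 differs from compound 4 in more than one place, so the effect of the core on growth inhibition also remains open.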